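Fused pyrrolidine alcohol and ether series, alpha3/beta4 binding

The source may hold more compounds than are shown below. What is called first, only, known or untested is meant among the compounds shown, and "the series" means these compounds.

Compound 1 `CO[C@H]1CC[C@H]2CCN(C)[C@H]2C1`: > 300000 nM (a limit of the assay)
Compound 2 `CCO[C@H]1CC[C@H]2CCN(C)[C@H]2C1`: 300000 nM
Compound 3 `CN1CC[C@@H]2CC[C@H](O)C[C@@H]21`: > 300000 nM (a limit of the assay)

Compound 3 stands in an assay on HEK293 cells for displacement of a labelled ligand from Neuronal acetylcholine receptor; alpha3/beta4 (Rattus norvegicus), with a stated time of 4 h (a higher number here means a weaker inhibitor, a lower number a stronger inhibitor), at a limit, > 300000 nM, so no number is known for it. Compound 1 likewise reaches only a limit in this assay, > 300000 nM. Compound 2 gives 300000 nM in this assay. The recorded steps within the set, a number no higher from compound 1 to compound 2 (the limit leaves the size open), a step that the two limits leave unreadable from compound 1 to compound 3 and a number no lower from compound 2 to compound 3 (the limit leaves the size open), all stay unreadable in size; the reason is that (the limit of > 300000 nM in this assay, at which 2 of the 3 values shown sit).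

Compound 4 `O[C@H]1CC[C@H]2CCN[C@H]2C1` differs from compound 3 by hydrogen in place of methyl on an amine nitrogen in a ring. Within the data shown here, none of the measured steps touches the amine nitrogen in a ring, so the set holds no step that bears on this change. Among the measured compounds shown here, what is known is only that every value in the set lies at or beside the limit of this assay.

The expectation for compound 4 is therefore no step beyond the scatter, a number no higher from compound 3 to compound 4 (the limit leaves the size open), with a good chance that only a limit is again reported. For compound 4 the estimated value in this assay is 300000 nM, between 50000 nM and 1500000 nM.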

Compound 4, inhibition constant: > 300000 nM
Compound 4: only a limit was reported; the forecaster's own chance of this, stated with the estimate: 70%; the middle value lies on the limit itself.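

Compound 3 and compound 4 both reach only a limit in this assay, so no size can be read for the step between them: the limit of > 300000 nM in this assay, at which 3 of the 4 values shown sit.

The compounds shown leave open whether hydrogen in place of methyl on the amine nitrogen in a ring changes the inhibition constant at all, and in which direction.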